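Piperidine sulfonyl group swap on compound 2

The compounds below may be only part of what the source reports. "The series", "measured", "known", "first", "only" and "open" are said of these compounds alone.

In an assay on CHO-K1 cells for displacement of a labelled ligand from melanin-concentrating hormone receptor 1 (Homo sapiens), read by scintillation proximity assay, with a stated time of 2 h (a higher number here means a weaker inhibitor, a lower number a stronger inhibitor), compound 2 `Cc1nc(N2CCC(N3CCCS3(=O)=O)CC2)nc2ccc(NC(=O)/C=C/c3ccc(OC(F)(F)F)cc3)cc12` gives 4 nM, the lowest of the three numbers recorded so far. Compound 1 `COc1ccc(/C=C/C(=O)Nc2ccc3nc(N4CCC(O)(C5CC5)CC4)nc(C)c3c2)cc1` gives 116 nM in this assay, and compound 3 `Cc1nc(N2CCC(O)(C3CC3)CC2)nc2ccc(NC(=O)/C=C/c3ccc(Cl)cc3Cl)cc12` gives 620 nM. Among the compounds with values here, the single measured step between compounds that differ in one place is a 5.3-fold higher number from compound 1 to compound 3 (0.73 log units; beyond the scatter); it concerns the aryl end of the unsaturated amide chain, not the substituent on the piperidine.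

Compound 4 `Cc1nc(N2CCC(NS(=O)(=O)N(C)C)CC2)nc2ccc(NC(=O)/C=C/c3ccc(OC(F)(F)F)cc3)cc12` is not yet measured. It differs from compound 2 in one place: a group of 7 heavy atoms (2 carbon, 2 nitrogen, 2 oxygen, 1 sulfur; no ring) in place of a group of 7 heavy atoms (3 carbon, 1 nitrogen, 2 oxygen, 1 sulfur; one five-membered non-aromatic ring with 2 hetero atoms), on a saturated ring carbon. Within the data shown here, no measured step bears on this position, so nothing in the numbers so far shows how much this assay responds to a change here. The replacement keeps a sulfonyl-bearing nitrogen substituent on the same saturated ring carbon and adds one hydrogen-bond donor while the ring is opened. Among the measured compounds shown here, with no step to anchor the direction, the expectation is that a 2.0-fold higher number from compound 2 to compound 4 (0.30 log units; within the scatter) stays within the scatter, or at most modest in either direction. On that basis compound 4 is expected to give 8 nM in this assay, with a range from 3 nM to 25 nM.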

Compound 4, half-maximal inhibitory concentration: 105 nM
Compound 4: the middle estimate sits 13-fold (1.12 log units) below what was measured, outside the stated range (above it).
By their numbers in this assay, from the lowest: compound 2; then compounds 4 and 1 (each within the scatter of the next); then compound 3.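

Position notes: the saturated ring carbon of the piperidine is sensitive to the choice of sulfonyl-bearing group in this assay, with a 26-fold higher number from compound 2 to compound 4 (1.42 log units; beyond the scatter) as the first measured step at this position. The two groups match in heavy-atom count and in hydrogen-bond acceptor count, so a sulfonyl-bearing nitrogen substituent on this carbon is not enough by itself to retain the low number of compound 2; the entering (dimethylsulfamoyl)amino group differs in having no ring, an extra nitrogen in place of a carbon and a hydrogen-bond donor. No available evidence accounts for the loss.

These differences change together in this single step, so the compounds shown cannot assign the loss to ring opening, to the added nitrogen or to the added donor; a methanesulfonylamino group, a fully N-methylated open-chain (dimethylsulfamoyl)amino group or a six-membered cyclic sulfonamide would each separate part of this. Both compounds also carry the same 4-trifluoromethoxyphenyl end, which leaves open whether a step of this size would recur with a 4-methoxyphenyl or 2,4-dichlorophenyl end.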